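Swapping the Dichlorophenyl for a Bromophenyl on a Shared Core

The compounds below may be only part of what the source reports. "The series", "measured", "known", "first", "only" and "open" are said of these compounds alone.

Of the compounds shown here, two have so far been measured in an assay on isolated protein for inhibition of phosphatidylinositol 4,5-bisphosphate 3-kinase catalytic subunit beta isoform (Homo sapiens); a higher number here means a weaker inhibitor, a lower number a stronger inhibitor. Compound 1 `COc1cccc(Nc2nccc(-c3ccc(Cl)c(Cl)c3)n2)c1` gives 741 nM. Compound 2 `O=[N+]([O-])c1ccc(Nc2nccc(-c3ccc(Cl)cc3Cl)n2)cc1` gives 938 nM; this is the higher of the two numbers, but its gap to compound 1 lies within the scatter of repeat measurements, so the two compounds cannot be separated on these data.

Compound 3 `O=[N+]([O-])c1ccc(Nc2nccc(-c3ccc(Br)cc3)n2)cc1` has not yet been measured. It differs from compound 2 in a single place: 4-bromophenyl in place of 2,4-dichlorophenyl on an aromatic carbon. Going by the values given here, no measured pair shows what this kind of change does, so the expectation for compound 3 rests on compound 2 alone and carries real uncertainty. Both measured compounds carry a ring with two chlorines, and compound 3 instead carries a ring with one bromine, so a small loss of potency seems somewhat more likely than a gain. The expected step of a 1.6-fold higher number from compound 2 to compound 3 (0.20 log units; within the scatter) is a modest weakening that may not exceed the scatter. Compound 3 is therefore estimated at 1500 nM, with a plausible range from 500 nM to 5000 nM.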

Compound 3, half-maximal inhibitory concentration: 961 nM
Compound 3: the middle estimate sits 1.6-fold (0.19 log units) above what was measured; measured number inside the range.
By their numbers in this assay, from the lowest: compounds 1, 2 and 3 (each within the scatter of the next).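

In this assay the exchange of 2,4-dichlorophenyl for 4-bromophenyl, on the aromatic carbon next to the ring nitrogen, is a 1.0-fold higher number from compound 2 to compound 3 (0.01 log units; within the scatter) and so the two compounds cannot be told apart. Going by these compounds alone, this is the first pair that differs in one place, and it shows that, with the rest of compound 2 held fixed, a ring with one bromine and a ring with two chlorines read alike at this position. The swap alters both the halogen and the number of halogens on the ring, yet the read-out does not separate the two rings, and nothing measured here explains that result.

Going by these compounds, whether any halogen is needed at this position remains open, since a plain phenyl ring or a phenyl ring carrying an amine or a carboxylic acid would test how far this tolerance extends. It is also unknown whether the same swap would read alike on the core of compound 1, which differs from compound 2 in more than one place and so gives no direct comparison.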